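Swapping the aryl group on the ring nitrogen of compound 3

The compounds below may be only part of what the source reports. "The series", "measured", "known", "first", "only" and "open" are said of these compounds alone.

Three compounds share one core and differ only in the aryl group on the amide-type nitrogen of the five-membered ring. In a functional assay on 143B cells (Homo sapiens) for inhibition, read by CCK-8 assay, with a stated time of 72 h, tested at 1 uM (on this read-out higher numbers stand for more inhibition at the one concentration tested (going by the name of the read-out) and lower numbers for less inhibition), compound 1 `COc1ccc(F)cc1N1C(=O)CSC1c1cccc(C(=O)NCCCCc2ccccc2)c1` gives 62% and compound 2 `O=C(NCCCCc1ccccc1)c1cccc(C2SCC(=O)N2c2ccccc2)c1` gives 60%. Compound 3 `COc1cc(F)ccc1N1C(=O)CSC1c1cccc(C(=O)NCCCCc2ccccc2)c1` gives 63% in this assay, a figure that sits within the usual scatter of both neighbours: a number 1 percentage points higher from compound 1 to compound 3 (within the scatter) and a number 3 percentage points higher from compound 2 to compound 3 (within the scatter), and likewise a number 2 percentage points lower from compound 1 to compound 2 (within the scatter).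

Compound 4 `O=C(NCCCCc1ccccc1)c1cccc(C2SCC(=O)N2c2ccccc2F)c1` differs from compound 3 in one place: 2-fluorophenyl in place of 4-fluoro-2-methoxyphenyl on an amide-type nitrogen in a ring. All three measured steps bear on this change, since each of them also exchanges the aryl group on that ring nitrogen, and none of them moved this assay beyond the scatter. The change from a 4-fluoro-2-methoxyphenyl to a 2-fluorophenyl is therefore not expected to shift this assay beyond the scatter, so compound 4 is estimated at 61% with a range of 50% to 71%. The expected step is a number 2 percentage points lower from compound 3 to compound 4 (within the scatter).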

Compound 4, a percentage reported as inhibition, at one concentration (the size of the read-out at that concentration, not a potency): 59%
Beside the measured number, compound 4's estimate is 2 percentage points above it; low and high end bracket the measured number.
By their numbers in this assay, from the lowest: compounds 4, 2, 1 and 3 (each within the scatter of the next).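

In this assay the 2-fluorophenyl group gives a fourth aryl group on the amide-type nitrogen in a ring, and it stays within the scatter of both methoxy-bearing compounds (a number 4 percentage points lower from compound 3 to compound 4 (within the scatter)) and (a number 3 percentage points lower from compound 1 to compound 4 (within the scatter)). For the compounds shown here, the step (a number 1 percentage points lower from compound 2 to compound 4 (within the scatter)) is the first change here of a single atom, fluoro in place of hydrogen on an aromatic carbon, and it too stays within the scatter. Fluoro therefore leaves the read-out within the scatter at this position even with no methoxy group on the ring.

As far as these compounds go, whether a more different group here, such as an aryl ring bearing an amine or a carboxylic acid, would move the number beyond the scatter remains open. Nothing available explains why these four aryl groups read alike.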